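The source may hold more compounds than are shown below. What is called first, only, known or untested is meant among the compounds shown, and "the series" means these compounds.

Going by the values given here, compound 2, `C=C1C(=O)S[C@H](CCCCCCCCCC)[C@H]1C(=O)O`, is the stronger of the two compounds measured so far: in an assay for inhibition of fatty acid synthase (Rattus norvegicus) (a lower number here means a stronger inhibitor, a higher number a weaker inhibitor), compound 2 gives 1190 nM, whereas compound 1, `C=C1C(=O)S[C@H](CCCCCCCC)[C@H]1C(=O)O`, gives 2560 nM. Among the compounds with values here, the single measured step, a 2.2-fold lower number from compound 1 to compound 2 (0.33 log units; beyond the scatter), came with ethyl in place of hydrogen on the saturated chain. Compound 3, `C=C1C(=O)S[C@H](CCCCCCCCCCC)[C@H]1C(=O)O`, lengthens the same chain by a smaller piece: methyl in place of hydrogen on a saturated chain carbon, ten or more bonds along the chain from a saturated ring carbon. Because the earlier lengthening gave only the modest gain of a 2.2-fold lower number from compound 1 to compound 2 (0.33 log units; beyond the scatter), adding a single methyl is expected to bring a smaller change in the same direction, one that may well stay within the scatter of this assay. For compound 3 a value of 850 nM is therefore estimated in this assay, with a likely range from 450 nM to 1600 nM. The expected step is a 1.4-fold lower number from compound 2 to compound 3 (0.15 log units; within the scatter).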

Compound 3, half-maximal inhibitory concentration: 790 nM
The estimate for compound 3 lay 1.1-fold (0.03 log units) above the measured number; the measured number falls inside the stated range.
By their numbers in this assay, from the lowest: compounds 3 and 2 (each within the scatter of the next); then compound 1.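

The single methyl gives a 1.5-fold lower number from compound 2 to compound 3 (0.18 log units; within the scatter) in this assay, so this last small addition cannot be told apart from the scatter of the measurement. The whole extension gives a 3.2-fold lower number from compound 1 to compound 3 (0.51 log units; beyond the scatter), which shows that the gain from a longer chain holds up over these three compounds, though it remains modest. No outside measurement is available to explain these numbers.

Still open, from the compounds shown here alone, is whether a longer chain would lower the number further, leave it unchanged or raise it. Going by these compounds, the effect of an amine or a phenyl ring carried on this chain also remains unknown.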